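This account rests on a few compounds, and the source may have more. Where it says the series, first, only, none or still open, it means among the compounds named here.

compound 1 `CC(C)=CCOc1cc(O)c2c(c1)OC(c1ccccc1)CC2=O` gives 7320 nM
compound 2 `CC(C)=CCOc1cc(O)c2c(c1)OC(c1ccccc1Cl)CC2=O` gives 4270 nM
compound 3 `CC(C)=CCOc1cc(O)c2c(c1)OC(c1cccc(Br)c1)CC2=O` gives 4040 nM

In a functional assay (on this read-out lower numbers stand for stronger inhibition and higher numbers for weaker inhibition), compound 3 gives 4040 nM, which is not separated from the other two values: a 1.8-fold lower number from compound 1 to compound 3 (0.26 log units; within the scatter) and a 1.1-fold lower number from compound 2 to compound 3 (0.02 log units; within the scatter).

Next in the series is compound 4 `CC(C)=CCOc1cc(O)c2c(c1)OC(c1ccc(C)cc1)CC2=O`, with the change (4-methylphenyl in place of 3-bromophenyl on a saturated ring carbon). This places 4-methylphenyl in place of 3-bromophenyl on a saturated ring carbon, next to the ring oxygen. Among the measured compounds shown here, no measured compound carries 4-methylphenyl, so the evidence is indirect. The bearing steps are the chloro step a 1.7-fold lower number from compound 1 to compound 2 (0.23 log units; within the scatter), the bromo step a 1.8-fold lower number from compound 1 to compound 3 (0.26 log units; within the scatter) and the exchange of aryl groups a 1.1-fold lower number from compound 2 to compound 3 (0.02 log units; within the scatter). All three are small, so no step beyond the scatter is expected in this assay, and no direction can be firmly assigned. The expected step is a 1.2-fold higher number from compound 3 to compound 4 (0.07 log units; within the scatter). Compound 4 is estimated at 4800 nM, with an expected range from 2500 nM to 9000 nM.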

Compound 4, half-maximal inhibitory concentration: 4360 nM
Estimate against measurement, compound 4: 1.1-fold (0.04 log units) above; low and high end bracket the measured number.
By their numbers in this assay, from the lowest: compounds 3, 2, 4 and 1 (each within the scatter of the next).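

In this assay, the 4-methylphenyl group on the saturated ring carbon, next to the ring oxygen, is not separated from the halogen-bearing aryl groups (a 1.1-fold higher number from compound 3 to compound 4 (0.03 log units; within the scatter); a 1.0-fold higher number from compound 2 to compound 4 (0.01 log units; within the scatter)). Against the unsubstituted phenyl, the methyl step (a 1.7-fold lower number from compound 1 to compound 4 (0.23 log units; within the scatter)) likewise stays unresolved, as the chloro and bromo steps did. A group of carbon only therefore gives the same picture as chloro or bromo at this position, and a halogen is not required to stay within the scatter of these four compounds.

No measurement available here accounts for these values. As far as these compounds go, whether an amine or a carboxylic acid on this aryl ring, or a longer chain in place of the methyl, would move the number beyond the scatter remains open.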